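Swapping Amino for Nitro: An Expected Cytotoxicity Value

A few compounds are considered here, and "the series" means these few. Any claim that something is new, unique, unknown or untested is made for them only; others in the source may bear on it.

Compound 1 `O=C(NC(=S)Nc1nc2cc([N+](=O)[O-])ccc2s1)N1CCOCC1`: 31000 nM
Compound 2 `Nc1ccc2sc(NC(=S)NC(=O)c3cccs3)nc2c1`: 28400 nM
Compound 3 `Nc1ccc2sc(NC(=S)NC(=O)N3CCOCC3)nc2c1`: 26400 nM

In a functional assay on MCF7 cells (Homo sapiens) for cytotoxicity, read by MTT assay, with a stated time of 24 h (a lower number here means a stronger inhibitor, a higher number a weaker inhibitor), compound 2 gives 28400 nM, a number that sits between those of compound 1 and compound 3, all three within the scatter of one another. Compound 4 `O=C(NC(=S)Nc1nc2cc([N+](=O)[O-])ccc2s1)c1cccs1` differs from compound 2 by nitro in place of amino on an aromatic carbon. The measured step that bears on this change is its reverse, a 1.2-fold lower number from compound 1 to compound 3 (0.07 log units; within the scatter), which lies within the scatter. The remaining step, a 1.1-fold lower number from compound 2 to compound 3 (0.03 log units; within the scatter), concerns the carbonyl substituent and also lies within the scatter. The number for compound 4 is therefore expected to stay close to that of compound 2, with no step beyond the scatter, a 1.1-fold higher number from compound 2 to compound 4 (0.02 log units; within the scatter). Compound 4 is estimated at 30000 nM, with a range from 15000 nM to 60000 nM.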

Compound 4, half-maximal inhibitory concentration: 35900 nM
For compound 4 the middle estimate is 1.2-fold (0.08 log units) below the measured one, within the range that was stated.
By their numbers in this assay, from the lowest: compounds 3, 2, 1 and 4 (each within the scatter of the next).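

In this assay, the exchange of amino and nitro on an aromatic carbon can now be read on a second core, as a 1.3-fold higher number from compound 2 to compound 4 (0.10 log units; within the scatter), and it agrees with the earlier step: the same change on two cores in this assay, a 1.2-fold lower number (0.07 log units; within the scatter) from compound 1 to compound 3 and a 1.3-fold lower number (0.10 log units; within the scatter) from compound 4 to compound 2, 1.1-fold (0.03 log units) apart, within the scatter of two such steps. The carbonyl substituent can also be read twice, with thiophen-2-yl in place of morpholin-4-yl giving a 1.2-fold higher number from compound 1 to compound 4 (0.06 log units; within the scatter): the same change on two cores in this assay, a 1.1-fold lower number (0.03 log units; within the scatter) from compound 2 to compound 3 and a 1.2-fold lower number (0.06 log units; within the scatter) from compound 4 to compound 1, 1.1-fold (0.03 log units) apart, within the scatter of two such steps. In these four compounds, neither change at either place goes beyond the scatter. From the compounds shown here alone, whether a carboxylic acid or a methoxy group on this aromatic carbon would give a step beyond the scatter stays open.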